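Chain extension on the sulfanyl side chain of a diaryl core

The compounds below may be only part of what the source reports. "The series", "measured", "known", "first", "only" and "open" are said of these compounds alone.

Measured so far:
compound 1 `CCCCCCCNc1cc(-c2ccccc2)c(-c2ccccc2)nn1` — 55000 nM
compound 2 `CCCCCCSc1cc(-c2ccccc2)c(-c2ccccc2)nn1` — 62000 nM

In an assay on microsomes from liver for inhibition of sterol O-acyltransferase 1 (Rattus norvegicus) (on this read-out lower numbers stand for stronger inhibition and higher numbers for weaker inhibition), compound 1 gives 55000 nM and compound 2 gives 62000 nM. For the measured compounds named here, the one step between them, a 1.1-fold higher number from compound 1 to compound 2 (0.05 log units; within the scatter), places the two numbers within the scatter of each other, so compound 2 stands alongside compound 1 rather than apart from it.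

Compound 3 `CCCCCCCCCSc1cc(-c2ccccc2)c(-c2ccccc2)nn1` differs from compound 2 by propyl in place of hydrogen on a saturated chain carbon, six bonds along the chain from a sulfur. Going by the values given here, no measured step alters chain length on this core; the only step, from compound 1 to compound 2, swaps the linking group and the chain together and is within the scatter. Nothing in the two numbers therefore points to a change beyond the scatter in this assay, in either direction, for compound 3.

On that basis compound 3 is expected at 50000 nM, with a range of 20000 nM to 150000 nM, which means an estimated step of a 1.2-fold lower number from compound 2 to compound 3 (0.09 log units; within the scatter).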

Compound 3, half-maximal inhibitory concentration: 116000 nM
Beside the measured number, compound 3's estimate is 2.3-fold (0.37 log units) below it; low and high end bracket the measured number.
By their numbers in this assay, from the lowest: compounds 1, 2 and 3 (each within the scatter of the next, the first and the last beyond it).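

In this assay, propyl in place of hydrogen on a saturated chain carbon, six bonds along the chain from a sulfur, gives a 1.9-fold higher number from compound 2 to compound 3 (0.27 log units; within the scatter). For the compounds shown here, this is the first step that alters the chain alone while the sulfur link and the shared core stay fixed, and the added propyl does not carry the number beyond the scatter at this position. Nothing measured here speaks to what lies behind this step.

As far as these compounds go, whether a shorter chain such as butyl, or an amine or a carboxylic acid carried on the chain, would move the number beyond the scatter stays open. Also open, from the compounds shown here alone, is whether the same propyl gives a comparable step on the amino-linked chain of compound 1.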